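Trifluoromethyl for bromo on an anilino ring

The source may report more compounds than this note shows. Statements on the series, on what has been measured and on what is new or still open speak of the compounds shown alone.

Measured compounds:
- Compound 1 `C=CC(=O)Nc1cccc(NC(=O)CSc2nc(Nc3ccccc3Cl)c3ccccc3n2)c1`: 12700 nM
- Compound 2 `C=CC(=O)Nc1cccc(NC(=O)CSc2nc(Nc3ccc(F)cc3)c3ccccc3n2)c1`: 9490 nM
- Compound 3 `C=CC(=O)Nc1cccc(NC(=O)CSc2nc(Nc3ccc(Br)cc3)c3ccccc3n2)c1`: 17300 nM

All three were tested in a functional assay on MDA-MB-231 cells (Homo sapiens) for inhibition, read by MTT assay, with a stated time of 72 h; on this read-out lower numbers stand for stronger inhibition and higher numbers for weaker inhibition. Compound 3 gives the highest of the three numbers, but its separation from the others is small: a 1.4-fold higher number from compound 1 to compound 3 (0.13 log units; within the scatter) and a 1.8-fold higher number from compound 2 to compound 3 (0.26 log units; within the scatter), so no ordering among them can be claimed.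

Compound 4 `C=CC(=O)Nc1cccc(NC(=O)CSc2nc(Nc3ccc(C(F)(F)F)cc3)c3ccccc3n2)c1` differs from compound 3 in one place: trifluoromethyl in place of bromo on an aromatic carbon. The change keeps the shared core and the anilino nitrogen untouched and alters only the group on the aromatic carbon of the six-membered ring, in the position described as para to a large group.

Within the data shown here, the steps that bear on this are the swaps among halogenated anilines, a 1.3-fold lower number from compound 1 to compound 2 (0.13 log units; within the scatter), a 1.4-fold higher number from compound 1 to compound 3 (0.13 log units; within the scatter) and a 1.8-fold higher number from compound 2 to compound 3 (0.26 log units; within the scatter), each within the scatter. Nothing in these measurements points to a substituent in this position moving the number beyond the scatter, so for compound 4 the expected step is a 1.2-fold lower number from compound 3 to compound 4 (0.06 log units; within the scatter), essentially none. Compound 4 is therefore estimated at 15000 nM, with a range from 6000 nM to 40000 nM.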

Compound 4, half-maximal inhibitory concentration: 11500 nM
Compound 4: middle estimate off by 1.3-fold (0.12 log units), on the high side; low and high end bracket the measured number.
By their numbers in this assay, from the lowest: compounds 2, 4, 1 and 3 (each within the scatter of the next).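

In this assay, trifluoromethyl, with 4 heavy atoms in place of the single bromine, stays level with bromo on this aromatic carbon (a 1.5-fold lower number from compound 3 to compound 4 (0.18 log units; within the scatter)). It also stays level with the fluoro compound (a 1.2-fold higher number from compound 2 to compound 4 (0.08 log units; within the scatter)) and with the 2-chlorophenyl compound (a 1.1-fold lower number from compound 1 to compound 4 (0.04 log units; within the scatter)), so a group of several atoms joins the halogens here without any step beyond the scatter. No measurement is available to say why these numbers stay so close.

The compounds shown leave open whether an amine, a carboxylic acid or a longer alkyl chain on this aromatic carbon would move the number beyond the scatter. Also open, as far as these compounds go, is whether trifluoromethyl would read the same on the ring carbon that carries chloro in compound 1.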